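The source may hold more compounds than are shown below. What is called first, only, known or untested is meant among the compounds shown, and "the series" means these compounds.

Measured so far:
compound 1 `CCOC(=O)[C@H](CCC(=O)O)NC(=O)c1ccc(Sc2nc3cc(N)cc(N)c3nc2-c2ccccc2)cc1`: < 100000 nM
compound 2 `Nc1cc(N)c2nc(-c3ccccc3)c(Sc3ccc(F)cc3)nc2c1`: 70800 nM

Among the compounds with values here, in a functional assay on NCI-H322M cells (Homo sapiens) for inhibition, read by sulforhodamine B assay, with a stated time of 48 h (on this read-out lower numbers stand for higher toxicity in this test and higher numbers for lower toxicity in this test), compound 2 gives 70800 nM, the only plain number in the set. Compound 1 gives only a limit of the assay, < 100000 nM, in this assay; that is the limit of < 100000 nM in this assay, at which 1 of the 2 values shown sits. Compound 3 `COc1ccc(Sc2nc3cc(N)cc(N)c3nc2-c2ccccc2)cc1` is not yet measured; it differs from compound 2 by methoxy in place of fluoro on an aromatic carbon. Within the data shown here, no measured step exists between two compounds here, so the size of a step in this assay cannot be read from the data; for a change of this kind a step within the scatter is expected, with no clear direction. Compound 3 is therefore estimated at 60000 nM, between 25000 nM and 150000 nM, an expected step of a 1.2-fold lower number from compound 2 to compound 3 (0.07 log units; within the scatter).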

Compound 3, concentration lethal to 50% of the cells: < 100000 nM
Compound 3: only a limit was reported; the forecaster's own chance of this, stated with the estimate: 25%; the middle value lies beyond the limit too.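

Compound 3 gives only a limit of the assay, so no step from compound 2 to compound 3 can be read: the limit of < 100000 nM in this assay, at which 2 of the 3 values shown sit.

Still open, on these data alone, is whether methoxy in place of fluoro changes the read-out at all, and where compound 1 and compound 3 actually lie.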